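Working notes: replacing 4-acetylphenyl with 3-nitrophenyl

This account rests on a few compounds, and the source may have more. Where it says the series, first, only, none or still open, it means among the compounds named here.

compound 1 `C#CC1=CC[C@]2(CC1)C(=C)CC[C@H]2C(C)C` gives 97600 nM
compound 2 `C=C1CCC[C@]2(C)CCC(c3cn(-c4ccc(OC)cc4)nn3)=CC[C@@]12C` gives 43600 nM
compound 3 `C=C1CCC[C@]2(C)CCC(c3cn(-c4ccc(C(C)=O)cc4)nn3)=CC[C@@]12C` gives 15100 nM

In a functional assay on HeLa cells (Homo sapiens) for cytotoxicity, read by MTT assay, with a stated time of 48 h (on this read-out lower numbers stand for stronger inhibition and higher numbers for weaker inhibition), compound 3 has the lowest of the three numbers, with compound 2 nearest and compound 1 furthest. Compound 4 `C=C1CCC[C@]2(C)CCC(c3cn(-c4cccc([N+](=O)[O-])c4)nn3)=CC[C@@]12C` carries 3-nitrophenyl in place of 4-acetylphenyl on an aromatic nitrogen. For the measured compounds named here, only one measured step bears on this: a 2.9-fold lower number from compound 2 to compound 3 (0.46 log units; beyond the scatter) with acetyl in place of methoxy on an aromatic carbon. Going by the values given here, no measured compound carries nitro. A step of similar modest size is therefore expected in this assay, more likely upward, with compound 3 at 15100 nM the lowest so far. The expected step is a 1.6-fold higher number from compound 3 to compound 4 (0.20 log units; within the scatter) by this estimate. For compound 4 the estimate is 24000 nM with an expected range from 10000 nM to 55000 nM in this read-out.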

Compound 4, half-maximal inhibitory concentration: 31900 nM
Compound 4: middle estimate off by 1.3-fold (0.12 log units), on the low side; measured number inside the range.
By their numbers in this assay, from the lowest: compound 3; then compounds 4 and 2 (each within the scatter of the next); then compound 1.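

In this assay, 3-nitrophenyl in place of 4-acetylphenyl on an aromatic nitrogen gives a 2.1-fold higher number from compound 3 to compound 4 (0.32 log units; beyond the scatter), so 4-acetylphenyl now stands apart from a second aryl group as well as from 4-methoxyphenyl. The exchange of 3-nitrophenyl for 4-methoxyphenyl gives a 1.4-fold lower number from compound 2 to compound 4 (0.14 log units; within the scatter), which does not separate these two groups. No measurement at hand accounts for either step.

This change alters both the group and where it sits on the phenyl ring, so the two contributions cannot be told apart. A 3-acetylphenyl, a 4-nitrophenyl or an amine on that ring would remain to be read.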